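Swapping the aromatic amide ring for a small alcohol

A few compounds are considered here, and "the series" means these few. Any claim that something is new, unique, unknown or untested is made for them only; others in the source may bear on it.

Compound 1 `CC1(C)Cc2c(sc(NC(=O)c3cccnc3O)c2C(N)=O)C(C)(C)O1` carries a 2-hydroxypyridin-3-yl group on the amide carbonyl of the shared core. In an assay on cells for positive allosteric modulation of Cystic fibrosis transmembrane conductance regulator variant F508del (Homo sapiens), with stated times of 10 min and 7 s, in the presence of a further agent that is not named here (a lower number here means that less compound is needed, a higher number that more compound is needed for the effect), compound 1 gives 190 nM. Compound 2 `CC1(C)Cc2c(sc(NC(=O)c3cn[nH]c3)c2C(N)=O)C(C)(C)O1`, with 1H-pyrazol-4-yl in that place, gives 125 nM in this assay, so the two stand close together: a 1.5-fold lower number from compound 1 to compound 2 (0.18 log units; within the scatter). Compound 3 `CC1(C)Cc2c(sc(NC(=O)C3CNC(=O)C3)c2C(N)=O)C(C)(C)O1`, carrying the non-aromatic 5-oxopyrrolidin-3-yl group, gives only a limit of the assay, > 10000 nM, namely (the limit of > 10000 nM in this assay, at which 1 of the 3 values shown sits). The steps to it are both large: an at least 52-fold higher number from compound 1 to compound 3 (1.72 log units; beyond the scatter) and an at least 80-fold higher number from compound 2 to compound 3 (1.90 log units; beyond the scatter).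

Compound 4 `CC1(C)Cc2c(sc(NC(=O)C(C)(C)CO)c2C(N)=O)C(C)(C)O1` has not been measured. It differs from compound 1 in one place: 1-(hydroxymethyl)-1-methylethyl in place of 2-hydroxypyridin-3-yl on a carbonyl carbon. As in compound 3, the aromatic ring on the carbonyl carbon gives way to a non-aromatic group, here a short chain without any ring. The two large steps to compound 3 are the ones that bear on this change, and a large rise in the number is therefore expected. For compound 4 the estimate in this assay is 8000 nM, between 1500 nM and 30000 nM, which means an expected step of a 42-fold higher number from compound 1 to compound 4 (1.62 log units; beyond the scatter), quite possibly reported only as a limit.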

Compound 4, half-maximal effective concentration: 75 nM
Compound 4: the middle estimate sits 110-fold (2.03 log units) above what was measured, outside the stated range (below it).
By their numbers in this assay, from the lowest: compounds 4, 2 and 1 (each within the scatter of the next, the first and the last beyond it). At a limit, above all of these: compound 3.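

An aromatic ring on the carbonyl carbon proves not to be required in this assay: the ringless 1-(hydroxymethyl)-1-methylethyl group gives a 2.5-fold lower number from compound 1 to compound 4 (0.40 log units; beyond the scatter), and a 1.7-fold lower number from compound 2 to compound 4 (0.22 log units; within the scatter). A non-aromatic group in this place therefore does not in itself bring a high number, for the two such groups shown are far apart, with an at least 130-fold lower number from compound 3 to compound 4 (2.12 log units; beyond the scatter). The value of compound 3 is a limit of the assay, not an exact number: the limit of > 10000 nM in this assay, at which 1 of the 4 values shown sits.

Going by these compounds, what the hydroxyl of compound 4 contributes stays open; a tert-butyl group, a chain with an amine or a carboxylic acid in place of the hydroxyl, or a longer chain would test it. The compounds shown also do not tell which feature of the 5-oxopyrrolidin-3-yl group sets compound 3 apart.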